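The source may hold more compounds than are shown below. What is called first, only, known or untested is meant among the compounds shown, and "the series" means these compounds.

Working notes on the series. Compound 1 `CCCCOC(=O)NS(=O)(=O)c1ccc(CCC)cc1-c1ccc(Cn2c(C3CCCCC3)nc3ccccc32)cc1`, compound 2 `CCCCOC(=O)NS(=O)(=O)c1ccc(CCC)cc1-c1ccc(Cn2cnc3ccccc32)cc1` and compound 3 `CCCCOC(=O)NS(=O)(=O)c1ccc(CCC)cc1-c1ccc(Cn2c(Cc3ccccc3)nc3ccccc32)cc1` share one core and differ only in what one aromatic carbon of that core carries: cyclohexyl, hydrogen or benzyl. In an assay on membranes from HEK293 cells for displacement of a labelled ligand from Type-2 angiotensin II receptor (Homo sapiens), read by radioligand binding (on this read-out lower numbers stand for stronger inhibition and higher numbers for weaker inhibition), compound 1 gives 130 nM, compound 2 gives 29 nM and compound 3 gives 15 nM. Compound 3 holds the lowest of the three numbers; the step of an 8.7-fold lower number from compound 1 to compound 3 (0.94 log units; beyond the scatter) is beyond the scatter, but the step of a 1.9-fold lower number from compound 2 to compound 3 (0.29 log units; within the scatter) is within it, so compound 3 and compound 2 cannot be separated on this read-out.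

Compound 4 `CCCCOC(=O)NS(=O)(=O)c1ccc(CCC)cc1-c1ccc(Cn2c(CC)nc3ccccc32)cc1` has not yet been measured in this assay. Relative to compound 3 the change is methyl in place of phenyl on a saturated chain carbon bound to an aromatic carbon. Within the data shown here, the steps that bear on this are those at the same aromatic carbon: a 4.5-fold lower number from compound 1 to compound 2 (0.65 log units; beyond the scatter) and an 8.7-fold lower number from compound 1 to compound 3 (0.94 log units; beyond the scatter) are both beyond the scatter, while a 1.9-fold lower number from compound 2 to compound 3 (0.29 log units; within the scatter) is not. Cyclohexyl therefore stands apart, and hydrogen and benzyl lie close together. Ethyl is expected to behave more like hydrogen and benzyl than like cyclohexyl. Compound 4 is therefore expected to give 20 nM in this assay, within 8 nM to 50 nM. The step this estimate implies, a 1.3-fold higher number from compound 3 to compound 4 (0.12 log units; within the scatter), is expected to remain within the scatter.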

Compound 4, inhibition constant: 11 nM
The estimate for compound 4 lay 1.8-fold (0.26 log units) above the measured number; measured number inside the range.
By their numbers in this assay, from the lowest: compounds 4, 3 and 2 (each within the scatter of the next, the first and the last beyond it); then compound 1.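

In this assay the phenyl of the benzyl group gives way to methyl, the change from benzyl to ethyl, with no readable shift: a 1.4-fold lower number from compound 3 to compound 4 (0.13 log units; within the scatter), so a ring on the saturated chain carbon is not required for a number in this range. Ethyl is also the only group so far that separates from hydrogen at this aromatic carbon, a 2.6-fold lower number from compound 2 to compound 4 (0.42 log units; beyond the scatter), which benzyl did not do, and its distance from cyclohexyl is large, a 12-fold lower number from compound 1 to compound 4 (1.07 log units; beyond the scatter), so among the groups shown, a small chain here reads better than hydrogen while cyclohexyl reads worse. No measurement at hand accounts for these differences.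

On these data alone, whether the gain over hydrogen holds for methyl, propyl or a longer chain remains open, as does what an amine or a carboxylic acid on the same carbon would give. Cyclohexyl is the only ring bound directly to this carbon here, so it is also open whether phenyl or cyclopropyl in that place would read like cyclohexyl or like ethyl.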